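A few compounds are considered here, and "the series" means these few. Any claim that something is new, unique, unknown or untested is made for them only; others in the source may bear on it.

Compound 2 `Cc1ccc(Cn2cc(COc3ccc4c(=O)ccoc4c3)nn2)cc1` gives > 100000 nM in a functional assay on MDA-MB-231 cells (Homo sapiens) for cytotoxicity, read by MTT assay, with a stated time of 48 h (on this read-out lower numbers stand for stronger inhibition and higher numbers for weaker inhibition), which is a limit of the assay and not a number. Compound 3 `O=c1ccoc2cc(OCc3cn(Cc4cccc(Br)c4)nn3)ccc12` gives > 100000 nM, and this too is a limit. For the measured compounds named here, the only true number so far comes from compound 1 `Cc1cccc(Cn2cc(COc3ccc4c(=O)ccoc4c3)nn2)c1`, which gives 16000 nM.

Compound 4 `O=c1ccoc2cc(OCc3cn(Cc4cccc(F)c4)nn3)ccc12` has not yet been measured. It carries 3-fluorophenyl in place of 4-methylphenyl on a saturated chain carbon bound to an aromatic nitrogen.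

Going by the values given here, three measured steps bear on this change. Putting 4-methylphenyl in place of 3-methylphenyl gave an at least 6.2-fold higher number from compound 1 to compound 2 (0.79 log units; beyond the scatter), and bromo in place of methyl gave an at least 6.2-fold higher number from compound 1 to compound 3 (0.79 log units; beyond the scatter). The comparison nearest to the new change, 3-bromophenyl in place of 4-methylphenyl, gives a step that the two limits leave unreadable from compound 2 to compound 3. Compound 4 keeps a group named like those of compound 1 and compound 3, yet these two ended far apart, so only a modest gain in this assay is likely, and the assay may again report only a limit.

The expected change is an at least 1.6-fold lower number from compound 2 to compound 4 (0.22 log units; that floor lies within the scatter), towards stronger inhibition. For compound 4 the estimate is 60000 nM, with an expected range of 15000 nM to 150000 nM.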

Compound 4, half-maximal inhibitory concentration: > 100000 nM
Compound 4 ended at the assay's limit; the forecaster's own chance of this, stated with the estimate: 50%; at least 1.6-fold (0.22 log units) between middle value and limit.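

When the methyl group gives way to a fluoro group, this assay shows an at least 6.2-fold higher number from compound 1 to compound 4 (0.79 log units; beyond the scatter), so a second replacement of the methyl in 3-methylphenyl has lost the readable value of compound 1. Compound 4 gives > 100000 nM, which is a limit of the assay and not a number. The steps among compound 2, compound 3 and compound 4 cannot be read, so no order among these three can be given, and compound 1 remains the only compound with a true number: the limit of > 100000 nM in this assay, at which 3 of the 4 values shown sit.

Going by these compounds, what stays open is whether the methyl of compound 1 is unusual in itself or whether other small groups in its place would also give a readable value. A methoxy group, an ethyl group or an amine on that ring could answer this, and any of them might again end at the limit.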